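Swapping phenyl for pentyl on the alkyne of compound 2

A few compounds are considered here, and "the series" means these few. Any claim that something is new, unique, unknown or untested is made for them only; others in the source may bear on it.

Compound 1 `C=Cc1cn([C@H]2C[C@H](O)[C@@H](CO)O2)c(=O)[nH]c1=O` gives 14200 nM in an ADME assay on L1210/0 cells (Mus musculus) for cytotoxicity, with a stated time of 48 h; a lower number here means a stronger inhibitor, a higher number a weaker inhibitor. Compound 2 `O=c1[nH]c(=O)n([C@H]2C[C@H](O)[C@@H](CO)O2)cc1C#Cc1ccccc1` differs from it by 2-phenylethynyl in place of vinyl on an aromatic carbon. In this assay compound 2 reaches only a limit of the assay, > 200000 nM. That change gave an at least 14-fold higher number from compound 1 to compound 2 (1.14 log units; beyond the scatter). Compound 3 `CCCCCC#Cc1cn([C@H]2C[C@H](O)[C@@H](CO)O2)c(=O)[nH]c1=O` carries pentyl in place of phenyl on a triple-bonded carbon. No measured step compares pentyl with phenyl on such a carbon, so the single step shown offers only a loose pointer. Compound 3 is therefore expected to remain weak, near 100000 nM (range 30000 nM to 300000 nM). The expected step is an at least 2.0-fold lower number from compound 2 to compound 3 (0.30 log units; that floor lies within the scatter).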

Compound 3, half-maximal inhibitory concentration: > 200000 nM
Compound 3 gave a limit, no number; the forecaster's own chance of this, stated with the estimate: 50%; middle value at least 2.0-fold (0.30 log units) from the limit.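

Replacing vinyl with hept-1-yn-1-yl gives in this assay an at least 14-fold higher number from compound 1 to compound 3 (1.14 log units; beyond the scatter), so the loss seen with 2-phenylethynyl does not depend on an aromatic ring at the end of the alkyne. Compound 3 reaches a limit of the assay, > 200000 nM, which is not a number. The step from phenyl to pentyl cannot be read, and the two groups cannot be ranked, because both compounds stand at one limit: the limit of > 200000 nM in this assay, at which 2 of the 3 values shown sit.

From the compounds shown here alone, what stays open is whether a shorter chain such as methyl, or an amine on the triple-bonded carbon, would bring a readable value back.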